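This account rests on a few compounds, and the source may have more. Where it says the series, first, only, none or still open, it means among the compounds named here.

In a functional assay on SK-BR-3 cells (Homo sapiens) for antiproliferative activity (on this read-out higher numbers stand for weaker inhibition and lower numbers for stronger inhibition), compound 1 `CC(C)=CCc1cc(C(=O)Nc2cc3ccc(OCC4CCCN(C)C4)c(C)c3oc2=O)ccc1O` gives 1300 nM. Compound 2 `CC(C)=CCc1cc(C(=O)Nc2cc3ccc(OCCCN4CCCCC4)c(C)c3oc2=O)ccc1O` reaches only the limit of the measurement, > 50000 nM, so no true number is known for it. Compound 2 thus sits at the limit of > 50000 nM in this assay, at which 1 of the 2 values shown sits. Within the data shown here, the single measured step, an at least 38-fold higher number from compound 1 to compound 2 (1.58 log units; beyond the scatter), shows how strongly a change on this side chain can weaken inhibition. Compound 3 `CC(C)=CCc1cc(C(=O)Nc2cc3ccc(OCCCN(C)C(C)C)c(C)c3oc2=O)ccc1O` has not yet been measured; it differs from compound 2 by isopropyl(methyl)amino in place of piperidin-1-yl on a saturated chain carbon, three bonds along the chain from an oxygen on an aromatic ring. Among the measured compounds shown here, no measured step matches this change, so the expectation rests only on compound 2 standing at the limit: with isopropyl(methyl)amino, which has no ring, in place of piperidin-1-yl, compound 3 is expected to stay close to that limit, with an expected step of an at least 1.2-fold lower number from compound 2 to compound 3 (0.09 log units; that floor lies within the scatter). Compound 3 is therefore estimated at 40000 nM, somewhere between 8000 nM and 200000 nM.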

Compound 3, half-maximal inhibitory concentration: 570 nM
For compound 3 the middle estimate is 70-fold (1.85 log units) above the measured one; measured number outside the range, below it.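

Changing piperidin-1-yl to isopropyl(methyl)amino at the end of the same chain brings the activity back, with an at least 87-fold lower number from compound 2 to compound 3 (1.94 log units; beyond the scatter). Going by these compounds, compound 2 holds only a limit, not a true number, so this step gives a minimum and its real size remains unknown: the limit of > 50000 nM in this assay, at which 1 of the 3 values shown sits. The other new step, a 2.3-fold lower number from compound 1 to compound 3 (0.36 log units; beyond the scatter), is modest, and compound 1 carries a ring in its 1-methylpiperidin-3-yl group yet still has a measured value, so a ring in the amine does not by itself abolish activity in these compounds.

Among these compounds, with only one amine without a ring among them, the compounds cannot show whether removing the ring or the particular isopropyl and methyl groups matters more. Dimethylamino, diethylamino or pyrrolidin-1-yl at the end of the same chain would help separate these two readings.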